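The source may report more compounds than this note shows. Statements on the series, on what has been measured and on what is new or still open speak of the compounds shown alone.

Measured so far in an assay on isolated protein for inhibition of Dipeptidyl peptidase 4 (Rattus norvegicus); on this read-out lower numbers stand for stronger inhibition and higher numbers for weaker inhibition:
Compound 1 `N#C[C@@H]1CCCN1C(=O)[C@@H]1C[C@H](NCc2ccccc2)CN1` gives 3 nM
Compound 2 `N#C[C@@H]1CCCN1C(=O)[C@@H]1C[C@H](NC(=O)c2ccccc2)CN1` gives 3.8 nM

Of the two, compound 2 shows the higher number, yet its gap to compound 1 lies within the scatter, so the pair cannot be told apart in this assay. Compound 3 `N#C[C@@H]1CCCN1C(=O)[C@@H]1C[C@H](NC(=O)Nc2ccccc2)CN1` carries anilino in place of phenyl on a carbonyl carbon. Among the measured compounds shown here, no measured pair shows this change, so its effect is unknown; the step is expected to be small, in either direction, and not beyond the scatter. The implied step a 1.3-fold higher number from compound 2 to compound 3 (0.12 log units; within the scatter) is thus expected to be modest. Compound 3 is estimated at 5 nM, in a range from 1.5 nM to 18 nM.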

Compound 3, half-maximal inhibitory concentration: 1.1 nM
Compound 3: the middle estimate sits 4.5-fold (0.66 log units) above what was measured; the measured number lies below the stated range.
By their numbers in this assay, from the lowest: compound 3; then compounds 1 and 2 (each within the scatter of the next).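

In this assay, anilino in place of phenyl on a carbonyl carbon gives a 3.5-fold lower number from compound 2 to compound 3 (0.54 log units; beyond the scatter), a step beyond the scatter. This shows that the position accepts the extra nitrogen and its hydrogen-bond donor with a gain, which the earlier pair could not show, since its two numbers could not be told apart. Nothing available accounts for this gain.

From the compounds shown here alone, whether the gain depends on the hydrogen of that nitrogen stays open, and a methylanilino or a phenoxy group on the same carbonyl carbon would bear on this. Also open, going by these compounds, is whether it would hold for a cyclohexylamino group.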